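Boronic acid series: trifluoromethyl to tert-butylsulfamoyl at the biaryl

The compounds below may be only part of what the source reports. "The series", "measured", "known", "first", "only" and "open" are said of these compounds alone.

Three compounds of a shared boronate core have numbers in an assay on isolated protein for inhibition of serine protease 1 (Homo sapiens); on this read-out higher numbers stand for weaker inhibition and lower numbers for stronger inhibition. Compound 1 `CC1(C)C2CC1[C@]1(C)OB([C@H](CCCN=C(N)N)NC(=O)c3ccc(-c4ccccc4)c(N)c3)O[C@@H]1C2` gives 4.7 nM. Compound 3 `CC1(C)C2CC1[C@]1(C)OB([C@H](CCCN=C(N)N)NC(=O)c3cccc(-c4cccc(NS(C)(=O)=O)c4)c3)O[C@@H]1C2` gives 3.8 nM. Compound 2 `Cc1cc(-c2ccccc2C(F)(F)F)ccc1C(=O)N[C@@H](CCCN=C(N)N)B1O[C@@H]2CC3CC(C3(C)C)[C@]2(C)O1` gives 3.1 nM, the lowest of the three, though its gaps to compound 1 and to compound 3 both lie within the scatter, so no order among them is claimed.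

Compound 4 `Cc1cc(-c2ccccc2S(=O)(=O)NC(C)(C)C)ccc1C(=O)N[C@@H](CCCN=C(N)N)B1O[C@@H]2CC3CC(C3(C)C)[C@]2(C)O1` is not yet measured. It differs from compound 2 by (tert-butyl)sulfamoyl in place of trifluoromethyl on an aromatic carbon. For the measured compounds named here, no measured pair shows this change, so its size is open. Given that compound 3 carries a sulfonamide and gives 3.8 nM, the step from compound 2 to compound 4 is expected to be a 1.5-fold higher number from compound 2 to compound 4 (0.16 log units; within the scatter), not beyond the scatter. Compound 4 is estimated at 4.5 nM, within 1.5 nM to 14 nM.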

Compound 4, inhibition constant: 0.7 nM
Compound 4: middle estimate off by 6.4-fold (0.81 log units), on the high side, and the stated range ends above it.
By their numbers in this assay, from the lowest: compound 4; then compounds 2, 3 and 1 (each within the scatter of the next).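

At this aromatic carbon, ortho to a large group, (tert-butyl)sulfamoyl in place of trifluoromethyl gives in this assay a 4.4-fold lower number from compound 2 to compound 4 (0.65 log units; beyond the scatter), the only step shown in the series. The position therefore accepts 8 heavy atoms in place of 4 with no loss on this read-out, and the number falls beyond the scatter. Nothing measured here gives a reason for the step.

Which part of the new group carries the step stays open. Plain sulfamoyl and methylsulfonyl at this carbon would separate the tert-butyl from the sulfonyl part.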